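The source may hold more compounds than are shown below. What is called first, only, known or untested is meant among the compounds shown, and "the series" means these compounds.

Compound 1 `COc1ccc(-n2nc(C(=O)N3CCCCC3)cc2-c2ccc(Cl)cc2)nn1`: 41 nM
Compound 2 `COc1ccc(-n2nc(CCC(=O)N3CCCCC3)cc2-c2ccc(Cl)cc2)nn1`: 920 nM

In a functional assay on a cell-free system (Platelet, plasma, Homo sapiens) for inhibition, read by turbidimetry, with a stated time of 3 min (on this read-out higher numbers stand for weaker inhibition and lower numbers for stronger inhibition), compound 2 has the higher of the two numbers, and compound 1 is its nearest neighbour. Compound 3 `COc1ccc(-n2nc(C(=O)N3CCCC3)cc2-c2ccc(Cl)cc2)nn1` differs from compound 2 as follows: (pyrrolidin-1-yl)carbonyl in place of 2-((piperidin-1-yl)carbonyl)ethyl on an aromatic carbon. Among the measured compounds shown here, the only measured step that bears on this is a 22-fold higher number from compound 1 to compound 2 (1.35 log units; beyond the scatter), which is large and beyond the scatter. Read in reverse, it points to a large move towards a lower number in this assay. For the measured compounds named here, no measured step covers the change from piperidinyl to pyrrolidinyl, so the estimate stays wide. The expected step is a 13-fold lower number from compound 2 to compound 3 (1.12 log units; beyond the scatter). For compound 3 the estimated value is 70 nM, with an expected range of 20 nM to 250 nM.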

Compound 3, half-maximal inhibitory concentration: 15 nM
The estimate for compound 3 lay 4.7-fold (0.67 log units) above the measured number; the whole stated range lies above it.
By their numbers in this assay, from the lowest: compound 3; then compound 1; then compound 2.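

In this assay, the carbonyl position responds to the ring on the amide as well as to the link: pyrrolidin-1-yl in place of piperidin-1-yl gives a 2.7-fold lower number from compound 1 to compound 3 (0.44 log units; beyond the scatter) as a modest step beyond the scatter. The wider replacement of 2-((piperidin-1-yl)carbonyl)ethyl gives a 61-fold lower number from compound 2 to compound 3 (1.79 log units; beyond the scatter) and exceeds either single comparison seen before. No measurement on hand gives a cause for either step. Open, going by these compounds, is how a morpholin-4-yl or azetidin-1-yl group on the carbonyl carbon compares, and whether a carboxylic acid or primary amine on this aromatic carbon keeps the low number.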